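Swapping the pendant aryl group in two related agonist cores

A few compounds are considered here, and "the series" means these few. Any claim that something is new, unique, unknown or untested is made for them only; others in the source may bear on it.

Measured compounds:
compound 1, `Cc1ccc(-c2cccc(COc3ccc(CCC(=O)O)cc3)c2)cc1`, 86%
compound 2, `Cc1ccc(-c2cccc(CNc3ccc(CCC(=O)O)cc3)c2)cc1`, 92%
compound 3, `COc1ccccc1-c1cccc(COc2ccc(CCC(=O)O)cc2)c1`, 105%

Of the compounds shown here, three have been measured in a functional assay on 1321-N1 cells for agonist activity at Free fatty acid receptor 1 (Homo sapiens), read by calcium flux; on this read-out lower numbers stand for smaller maximal responses and higher numbers for larger maximal responses. Compound 1 gives 86%, compound 2 gives 92% and compound 3 gives 105%. Compound 3 arises from compound 1 by a single change, (2-methoxyphenyl in place of 4-methylphenyl on an aromatic carbon), and that change made a number 19 percentage points higher from compound 1 to compound 3 (beyond the scatter). Compound 2 differs from compound 1 in its core; that difference is not broken down here. Compound 2 and compound 1 lie within the scatter of each other, while compound 3 stands above compound 2 by a gap that is beyond the scatter.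

The unmeasured compound 4 `COc1ccccc1-c1cccc(CNc2ccc(CCC(=O)O)cc2)c1` stands to compound 2 as compound 3 stands to compound 1. The change is 2-methoxyphenyl in place of 4-methylphenyl on an aromatic carbon, at the same place as before, so it is the same change. Because that change made a number 19 percentage points higher from compound 1 to compound 3 (beyond the scatter), a step of similar size is expected in this assay, roughly a number 15 percentage points higher from compound 2 to compound 4 (beyond the scatter). Compound 4 is therefore estimated at 107%, with an expected range from 95% to 119%.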

Compound 4, largest response reached (reported as efficacy), in percent of the reference or control that the assay uses: 109%
Beside the measured number, compound 4's estimate is 2 percentage points below it, and the stated range covers the measured number.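

In this assay the replacement of 4-methylphenyl by 2-methoxyphenyl gave a number 17 percentage points higher from compound 2 to compound 4 (beyond the scatter), so the change kept its direction on the second core. Set beside the earlier step, the two results agree in size: the same change on two cores in this assay, a number 19 percentage points higher (beyond the scatter) from compound 1 to compound 3 and a number 17 percentage points higher (beyond the scatter) from compound 2 to compound 4, 2 percentage points apart, within the scatter of two such steps. This shows that, for this one pair of groups and this one read-out of maximal response, the step carried from one core to the other, but two cores are too few to establish a general rule for the series, and the numbers do not explain why the step occurs.

The compounds shown leave open whether a similar step would appear with a different pendant group, such as one carrying a nitrile or a trifluoromethyl group, or on a core with an amide link or a longer chain leading to the carboxylic acid. They also leave open whether the change affects potency, which is a separate question from the largest response reached.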